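Working notes: replacing the aryl group on the methylidene arm

This account rests on a few compounds, and the source may have more. Where it says the series, first, only, none or still open, it means among the compounds named here.

Measured so far in a functional assay on MCF7 cells (Homo sapiens) for inhibition, read by MTT assay, with a stated time of 72 h, tested at 10 uM; a lower number here means less inhibition, a higher number more inhibition at the concentration tested (going by the name of the read-out):
- compound 1, `CCOC(=O)C1=C(Nc2ccccc2)S/C(=C\c2ccc([N+](=O)[O-])c(O)c2)C1=O`: 41.5%
- compound 2, `CCOC(=O)C1=C(Nc2ccccc2)S/C(=C\c2ccc(Br)c(O)c2)C1=O`: 16.4%
- compound 3, `CCOC(=O)C1=C(Nc2cccc(F)c2)S/C(=C\c2ccc[nH]2)C1=O`: reported only as a limit, < 10%

Among the two compounds with a number in this assay, compound 2 stands lowest; its nearest neighbour is compound 1, and the one single-place step recorded, a number 25.1 percentage points lower from compound 1 to compound 2 (beyond the scatter), runs from the higher to the lower of the two. Among the compounds with values here, compound 3 sits at the limit of this assay the limit of < 10% in this assay, at which 1 of the 3 values shown sits, and differs from compound 2 in more than one place, so no step to it can be read.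

Compound 4, `CCOC(=O)C1=C(Nc2ccccc2)S/C(=C\c2cc3ccncc3[nH]2)C1=O`, is not yet measured. Its change from compound 2 is a group of 9 heavy atoms (7 carbon, 2 nitrogen; one five-membered aromatic ring with 1 hetero atom, one six-membered aromatic ring with 1 hetero atom) in place of a group of 8 heavy atoms (6 carbon, 1 oxygen, 1 bromine; one six-membered aromatic ring of carbon only), on a double-bonded chain carbon bound to a double-bonded ring carbon. Within the data shown here, no measured step touches this part of the molecule; the only step in hand concerns the substituent on the ring that leaves, and it was modest. With the arm replaced outright, the numbers give no direction, and an expected step of a number 1.4 percentage points lower from compound 2 to compound 4 (within the scatter) from compound 2 to compound 4 is taken as within the scatter, with a real chance of a limit. Compound 4 is estimated at 15% in this assay, in the range 5% to 35%.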

Compound 4, a percentage reported as inhibition, at one concentration (the size of the read-out at that concentration, not a potency): 18.2%
Estimate against measurement, compound 4: 3.2 percentage points below, and the stated range covers the measured number.
By their numbers in this assay, from the lowest: compounds 2 and 4 (each within the scatter of the next); then compound 1. At a limit, below all of these: compound 3.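

In this assay, the step at the double-bonded chain carbon bound to a double-bonded ring carbon is a number 1.8 percentage points higher from compound 2 to compound 4 (within the scatter). The 4-bromo-3-hydroxyphenyl group can therefore be exchanged here for a group with one five-membered and one six-membered aromatic ring, each with 1 hetero atom, without a change in the number beyond the scatter. Within the data shown here, the earlier step changed only a substituent on the aryl ring and left that ring in place, so this is the first reading on replacing the whole arm, though it holds only for this one pair and gives no general rule for the position.

Open, from the compounds shown here alone, is whether a carboxylic acid or an amine on the entering group would shift the number in this assay, as the exchange of nitro and bromo shifted it on the aryl ring, and whether a simple phenyl or a pyridine ring on the arm would stay level with compound 2. Compound 3 is reported only as a limit and differs in more than one place, so steps to it cannot be read: the limit of < 10% in this assay, at which 1 of the 4 values shown sits.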